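Purine series: aromatic nitrogen substituent and HCT-116 antiproliferation

The compounds below may be only part of what the source reports. "The series", "measured", "known", "first", "only" and "open" are said of these compounds alone.

Measured so far:
compound 1 `COC(CCn1cnc2c(NCc3ccc(C(=O)Nc4ccccc4N)cc3)nc(Cl)nc21)OC` — 6.39%
compound 2 `Nc1ccccc1NC(=O)c1ccc(CNc2nc(Cl)nc3c2ncn3C2CCCC2)cc1` — 75.6%

For the measured compounds named here, in a functional assay on HCT-116 cells (Homo sapiens) for antiproliferative activity, read by CCK-8 assay, with a stated time of 72 h, tested at 2 uM (a lower number here means a weaker effect, a higher number a stronger effect of the compound at the concentration tested), compound 2 stands highest of the two numbers; the only neighbour, compound 1, sits a number 69.2 percentage points higher from compound 1 to compound 2 (beyond the scatter). Compound 3 `Nc1ccccc1NC(=O)c1ccc(CNc2nc(Cl)nc3c2ncn3Cc2ccccc2)cc1` is not yet measured; it differs from compound 2 by benzyl in place of cyclopentyl on an aromatic nitrogen. Going by the values given here, the single step bearing on this place, a number 69.2 percentage points higher from compound 1 to compound 2 (beyond the scatter), is large, so the substituent on this aromatic nitrogen matters, but no measured step exchanges cyclopentyl for benzyl. A moderate loss beyond the scatter is expected, a number 17.6 percentage points lower from compound 2 to compound 3 (beyond the scatter), with wide uncertainty. For compound 3 the estimate is 58%, range 25% to 85%.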

Compound 3, a percentage reported as inhibition, at one concentration (the size of the read-out at that concentration, not a potency): 7.7%
Compound 3: the middle estimate sits 50.3 percentage points above what was measured; measured number below the stated range.
By their numbers in this assay, from the lowest: compounds 1 and 3 (each within the scatter of the next); then compound 2.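

In this assay, benzyl in place of cyclopentyl on the aromatic nitrogen gives a number 67.9 percentage points lower from compound 2 to compound 3 (beyond the scatter), so a carbon-only ring group can lose the effect as fully as the acetal chain of compound 1 does. Compound 3 shows a number 1.3 percentage points higher from compound 1 to compound 3 (within the scatter), which leaves benzyl and 3,3-dimethoxypropyl not told apart and cyclopentyl alone high among the three groups. No evidence on hand accounts for this difference. As far as these compounds go, whether a cyclohexyl or an isopropyl group on this nitrogen keeps the effect of cyclopentyl remains open.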